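Swapping the amide side group of a fast-cleared compound

The source may hold more compounds than are shown below. What is called first, only, known or untested is meant among the compounds shown, and "the series" means these compounds.

Compound 1 `CC(=O)N[C@@H]1CCC[C@H](C(=O)Nc2cc(-c3cnn(C)c3C)c(Cl)cn2)C1` gives 3.3 mL.min-1.g-1
Compound 2 `CC(=O)N[C@@H]1CCC[C@H](C(=O)Nc2cc(-c3cnn4c3NCCC4)c(Cl)cn2)C1` gives 6.2 mL.min-1.g-1
Compound 3 `CC(=O)N[C@@H]1CCC[C@H](C(=O)Nc2cc(-c3cnn4c3CC(C)(C)C4)c(Cl)cn2)C1` gives 50 mL.min-1.g-1

These numbers come from an ADME assay on microsomes from liver (Homo sapiens) for metabolic stability (on this read-out higher numbers stand for fast clearance and lower numbers for slow clearance), and compound 3 stands highest of the three, so it is the fastest cleared here. Compound 4 `CC1(C)Cc2c(-c3cc(NC(=O)[C@H]4C[C@@H](O)C4)ncc3Cl)cnn2C1` differs from compound 3 on a carbonyl carbon, with 3-hydroxycyclobutyl in place of 3-acetamidocyclohexyl (3-hydroxycyclobutyl in place of 3-acetamidocyclohexyl on a carbonyl carbon).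

Among the compounds with values here, no measured step changes that place, so none gives a direct guide. Within the data shown here, all the measured steps concern the group on an aromatic carbon, and compound 4 keeps the group that compound 3 carries there. Two of those steps are large or modest, namely a 15-fold higher number from compound 1 to compound 3 (1.18 log units; beyond the scatter) and an 8.1-fold higher number from compound 2 to compound 3 (0.91 log units; beyond the scatter) in size, and both end at that group. Compound 4 is therefore expected to stay well above compound 1 (3.3 mL.min-1.g-1). The entering group is the smaller one, which gives a weak reason to expect a fall, though nothing measured here tests this. The expected change is a moderate fall (a 2.3-fold lower number from compound 3 to compound 4 (0.36 log units; beyond the scatter)), less than the largest measured step. Compound 4 is estimated at about 22 mL.min-1.g-1 in this assay with an expected range from 9 mL.min-1.g-1 to 55 mL.min-1.g-1 for repeated measurements.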

Compound 4, intrinsic clearance in microsomes: 25 mL.min-1.g-1
Compound 4: the middle estimate sits 1.1-fold (0.06 log units) below what was measured, and the stated range covers the measured number.
By their numbers in this assay, from the lowest: compounds 1 and 2 (each within the scatter of the next); then compounds 4 and 3 (each within the scatter of the next).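

Within the data shown here, this is the first measured change on the carbonyl carbon, and in this assay it gives a 2.0-fold lower number from compound 3 to compound 4 (0.30 log units; within the scatter). Although 3-hydroxycyclobutyl replaces 3-acetamidocyclohexyl, the two compounds cannot be told apart on this read-out, whereas a change to the group on an aromatic carbon gave a 15-fold higher number from compound 1 to compound 3 (1.18 log units; beyond the scatter). So, for this one pair, a much smaller group on the carbonyl carbon leaves the number within the usual scatter, and nothing available here explains this result.

From the compounds shown here alone, it remains open whether other groups on the carbonyl carbon, such as an aminocyclobutyl ring, a cyclobutyl ring carrying a carboxylic acid or a longer carbon chain, would also stay within the scatter of compound 3. Going by these compounds, it is equally open whether 3-hydroxycyclobutyl would behave the same way on the core of compound 1, which carries a different group on the aromatic carbon and has a much lower number in this assay.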